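The compounds below may be only part of what the source reports. "The series", "measured", "known", "first", "only" and "open" are said of these compounds alone.

Three compounds have been measured in a functional assay on PC-12 cells (Rattus norvegicus) for cytotoxicity, read by MTT assay, with stated times of 2 h and 24 h, tested at 1 uM; a higher number here means a stronger effect of the compound at the concentration tested, a lower number a weaker effect:

compound 1 `CC(C)c1ccc(-n2nc(-c3ccc(C(F)(F)F)cc3O)nc2-c2ccccc2O)cc1` gives 69.7%
compound 2 `Oc1cc(C(F)(F)F)ccc1-c1nc(-c2ccccc2O)n(-c2ccc(I)cc2)n1` gives 70.1%
compound 3 `COc1ccc(-n2nc(-c3ccc(C(F)(F)F)cc3O)nc2-c2ccccc2O)cc1` gives 69%

Compound 3 cannot be told apart from the other two: the steps of a number 0.7 percentage points lower from compound 1 to compound 3 (within the scatter) and a number 1.1 percentage points lower from compound 2 to compound 3 (within the scatter) both fall inside the scatter, as does a number 0.4 percentage points higher from compound 1 to compound 2 (within the scatter). Compound 4 `Oc1cc(C(F)(F)F)ccc1-c1nc(-c2ccccc2O)n(-c2ccccc2Cl)n1` carries 2-chlorophenyl in place of 4-methoxyphenyl on an aromatic nitrogen. The three measured steps all exchange the group on the phenyl attached to that aromatic nitrogen, and none moved the read-out beyond the scatter. Among the measured compounds shown here, no measured step changes the group's position on that phenyl, so the data give no direction. Compound 4 is therefore expected to show no change beyond the scatter in this assay, a step of no change at the digits printed from compound 3 to compound 4 (within the scatter). The estimate for compound 4 is 69%, between 59% and 79%.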

Compound 4, a percentage reported as activity, at one concentration (the size of the read-out at that concentration, not a potency): 70.1%
Beside the measured number, compound 4's estimate is 1.1 percentage points below it; the measured number falls inside the stated range.
By their numbers in this assay, from the lowest: compounds 3, 1, 2 and 4 (each within the scatter of the next).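

In this assay, 2-chlorophenyl on the aromatic nitrogen gives three steps, all within the scatter (a number 1.1 percentage points higher from compound 3 to compound 4 (within the scatter); no change at the digits printed from compound 2 to compound 4 (within the scatter); a number 0.4 percentage points higher from compound 1 to compound 4 (within the scatter)). So the one group shown with its substituent at the 2-position of this phenyl reads the same as the 4-substituted groups, and this position has now tolerated a change of place as well as a change of group. Nothing measured here accounts for this flat result.

No pair shown separates the chlorine from its place on the phenyl. On these data alone, whether an amine or a carboxylic acid on this phenyl would move the read-out beyond the scatter remains open.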